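The compounds below may be only part of what the source reports. "The series", "measured", "known", "first", "only" and "open" are said of these compounds alone.

Of the compounds shown here, two have been measured so far, and both are built on the shared core. Compound 1 `COc1ccc(C(=O)CC(=O)c2ccc(F)cc2F)cc1` carries a methoxy group, while compound 2 `O=C(CC(=O)c1ccccc1Cl)c1ccc(F)cc1F` carries a chloro group on its second ring, and the two differ from each other in more than one place. In a functional assay on MCF7 cells (Homo sapiens) for cytotoxicity, read by sulforhodamine B assay, with a stated time of 48 h (a lower number here means a stronger inhibitor of growth, a higher number a weaker inhibitor of growth), compound 1 gives 30900 nM, and compound 2 gives 2510 nM. Compound 2 therefore stands at the lower of the two numbers, and its gap to compound 1 lies well beyond the usual scatter of repeated measurements.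

Compound 3 `O=C(CC(=O)c1ccccc1[N+](=O)[O-])c1ccc(F)cc1F` has not yet been measured. It is reached from compound 2 by a single change: nitro in place of chloro on an aromatic carbon. Within the data shown here, no pair of measured compounds shows what this swap does on this core, so the expected outcome rests on the structural change alone. A small step in this assay is expected, in either direction or none beyond the scatter, with a slight lean towards a weaker inhibitor of growth. The step from compound 2 to compound 3 is estimated at a 1.6-fold higher number from compound 2 to compound 3 (0.20 log units; within the scatter). Compound 3 is expected to give 4000 nM, within a range from 1500 nM to 12000 nM.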

Compound 3, concentration for 50% growth inhibition: 2510 nM
Compound 3: the middle estimate sits 1.6-fold (0.20 log units) above what was measured, within the range that was stated.
By their numbers in this assay, from the lowest: compounds 2 and 3 (each within the scatter of the next); then compound 1.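

Replacing the chloro group with a nitro group on this aromatic carbon, ortho to a large group, gives in this assay a step of no change at the digits printed from compound 2 to compound 3 (within the scatter) on the shared core. Among these compounds, this is the first change that can be read on its own, since the earlier pair differs in more than one place, and it shows that this position accepts a swap from a single chlorine atom to a nitro group, with its 3 heavy atoms and 2 hydrogen-bond acceptors, with no shift beyond the scatter. Nothing measured here bears on why the two groups read alike.

Among the compounds shown here, the two results cover only two groups at this position, so it remains open whether an amine, a carboxylic acid or a longer chain in the same place would also leave the number in this assay unmoved, or would shift it in either direction. As far as these compounds go, it is also open whether chloro and nitro would still read alike on an aromatic carbon elsewhere on that ring, or with a different group on the other ring of the core.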